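A few compounds are considered here, and "the series" means these few. Any claim that something is new, unique, unknown or untested is made for them only; others in the source may bear on it.

Measured compounds:
compound 1, `COc1cc(-c2cc(/C=C/C(=O)c3ccc(Cl)c(Cl)c3)[nH]n2)cc(OC)c1OC`: -5%
compound 2, `COc1ccc(C(=O)/C=C/c2cc(-c3cc(OC)c(OC)c(OC)c3)n[nH]2)cc1OC`: -67%

In a functional assay on SW-620 cells (Homo sapiens) for cytotoxicity, read by sulforhodamine B assay, with a stated time of 48 h, tested at 100 uM (on this read-out lower numbers stand for a stronger effect and higher numbers for a weaker effect at the one concentration tested), compound 1 gives -5%, the highest of the two numbers. Compound 2 gives -67%. For the measured compounds named here, the one measured step, a number 62 percentage points lower from compound 1 to compound 2 (beyond the scatter), exchanges the aryl on the carbonyl carbon and shows that this position can move the read-out a long way.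

Compound 3, `COc1cc(-c2cc(/C=C/C(=O)c3ccc(F)c(F)c3)[nH]n2)cc(OC)c1OC`, has not yet been measured. It differs from compound 1 in one place: 3,4-difluorophenyl in place of 3,4-dichlorophenyl on a carbonyl carbon

Going by the values given here, no measured step exchanges 3,4-dichlorophenyl for 3,4-difluorophenyl, so there is no direct precedent. The step from compound 1 to compound 2 bears on it only in that the same position was changed there, with a large move toward lower numbers; a different group entering gives no guarantee of the same size or direction. The expectation is a step of uncertain size, more likely downward than upward, smaller than the measured one, and possibly within the scatter. For compound 3 the estimated value in this assay is -20%, with a range from -60% to 10%, meaning an expected step of a number 15 percentage points lower from compound 1 to compound 3 (beyond the scatter).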

Compound 3, a percentage reported as activity, at one concentration (the size of the read-out at that concentration, not a potency): 1%
Beside the measured number, compound 3's estimate is 21 percentage points below it, and the stated range covers the measured number.
By their numbers in this assay, from the lowest: compound 2; then compounds 1 and 3 (each within the scatter of the next).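

In this assay the exchange of 3,4-dichlorophenyl for 3,4-difluorophenyl on the carbonyl carbon gives a number 6 percentage points higher from compound 1 to compound 3 (within the scatter) and so leaves these two aryl groups indistinguishable at this position. The 3,4-dimethoxyphenyl group, by contrast, is separated from 3,4-difluorophenyl by a number 68 percentage points higher from compound 2 to compound 3 (beyond the scatter) and thus stands apart from both dihalogenated aryl groups, so the position is not sensitive to every exchange, and among these three compounds the large move belongs to compound 2 alone. No measurement at hand accounts for this difference between the aryl groups.

Still open, from the compounds shown here alone, is which feature of the 3,4-dimethoxyphenyl group carries the large step: an unsubstituted phenyl, or a phenyl bearing a single methoxy group, a hydroxyl, an amine or a carboxylic acid, on the same carbonyl carbon would show whether the read-out follows the methoxy groups specifically or responds to other substituents as well. Also open, going by these compounds, is whether the equivalence of 3,4-difluorophenyl and 3,4-dichlorophenyl extends to a phenyl carrying bromine or trifluoromethyl groups, and whether the separation from compound 2 persists at concentrations other than the single one tested here.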